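This account rests on a few compounds, and the source may have more. Where it says the series, first, only, none or still open, it means among the compounds named here.

Measured compounds:
Compound 1 `CCCN(CCC)c1nc(C(F)(F)F)ccc1CNC(=O)C(C)c1ccc(NS(C)(=O)=O)c(F)c1` — 14.7 nM
Compound 2 `C[C@H](C(=O)NCc1ccc(C(F)(F)F)nc1N1CCC[C@H]1CO)c1ccc(NS(C)(=O)=O)c(F)c1` — "not active" (no number reported)
Compound 3 `CC(C(=O)NCc1ccc(C(F)(F)F)nc1N1CCC(Cc2cc(F)cc(F)c2)CC1)c1ccc(NS(C)(=O)=O)c(F)c1` — 24 nM

In a functional assay on CHO-K1 cells for antagonist activity at transient receptor potential cation channel subfamily V member 1 (Homo sapiens), read by FLIPR (a lower number here means a stronger inhibitor, a higher number a weaker inhibitor), compound 1 gives 14.7 nM. Compound 3 gives 24 nM in this assay, and the gap between compound 1 and compound 3 falls within the usual scatter, so the two cannot be told apart on these numbers. Compound 2 is reported as "not active" (no number reported) in this assay, without a number, so it stands apart from the other two. Compound 1 therefore sits with compound 3 at the active end of what has been measured.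

Compound 4 `CC(C(=O)NCc1ccc(C(F)(F)F)nc1N1CCCCCC1)c1ccc(NS(C)(=O)=O)c(F)c1` has not yet been measured in this assay. It differs from compound 1 in one place: azepan-1-yl in place of dipropylamino on an aromatic carbon. Among the compounds with values here, the group that leaves and the group that enters carry the same count of heavy atoms, donors and acceptors; the only change is that the two propyl chains are joined into a seven-membered ring on the same position of the shared core. Within the data shown here, no measured pair shows such a step, so the expectation rests on the closeness of the two groups alone. Compound 4 is expected to land near compound 1, with a step of a 1.4-fold higher number from compound 1 to compound 4 (0.13 log units; within the scatter) that is not expected to reach beyond the scatter. The estimate for compound 4 in this assay is 20 nM, with a range from 7 nM to 60 nM.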

Compound 4, half-maximal inhibitory concentration: 25.1 nM
Compound 4: middle estimate off by 1.3-fold (0.10 log units), on the low side, and the stated range covers the measured number.
By their numbers in this assay, from the lowest: compounds 1, 3 and 4 (each within the scatter of the next).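

In this assay, azepan-1-yl in place of dipropylamino on this aromatic carbon, next to the ring nitrogen and ortho to a large group, gives a 1.7-fold higher number from compound 1 to compound 4 (0.23 log units; within the scatter). Within the data shown here, this is the first direct comparison at this position, and it shows that joining the two propyl chains into one seven-membered non-aromatic ring, with the heavy-atom count unchanged, gives a compound that cannot be told apart from its open-chain partner on these numbers. No accompanying measurement bears on this result, and it stands without an explanation.

The compounds shown leave open whether a smaller ring such as piperidin-1-yl, a ring with an added oxygen such as morpholin-4-yl, or longer chains such as dibutylamino would also stay within the scatter of compound 1 at this position. A single pair also cannot tell whether the same replacement would give a similar step with a different group in place of the trifluoromethyl group or the methanesulfonamide.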